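A methyl on the piperidine ring of compound 2

The source may hold more compounds than are shown below. What is called first, only, known or untested is meant among the compounds shown, and "the series" means these compounds.

Measured compounds:
compound 1 `COc1cc2c(Oc3ccc(NC(=O)c4nn(-c5ccccc5C)c(=O)cc4C)cc3F)ccnc2cc1OCCCN1CCC(C)CC1` — 1460 nM
compound 2 `COc1cc2c(Oc3ccc(NC(=O)c4nn(-c5ccccc5C(F)(F)F)c(=O)cc4C)cc3F)ccnc2cc1OCCCN1CCCCC1` — 140 nM

In a functional assay on A549 cells (Homo sapiens) for inhibition, read by MTT assay, with a stated time of 72 h (on this read-out higher numbers stand for weaker inhibition and lower numbers for stronger inhibition), compound 2 gives 140 nM, the lower of the two numbers. Compound 1 gives 1460 nM, and that gap lies beyond the scatter. Compound 3 `COc1cc2c(Oc3ccc(NC(=O)c4nn(-c5ccccc5C(F)(F)F)c(=O)cc4C)cc3F)ccnc2cc1OCCCN1CCC(C)CC1` is not yet measured. It differs from compound 2 by methyl in place of hydrogen on a saturated ring carbon. Within the data shown here, no measured pair isolates this change on its own. The expected step in this assay is a 1.3-fold higher number from compound 2 to compound 3 (0.11 log units; within the scatter), none beyond the scatter in either direction. Compound 3 is therefore estimated at 180 nM, with a range from 60 nM to 600 nM.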

Compound 3, half-maximal inhibitory concentration: 160 nM
The estimate for compound 3 lay 1.1-fold (0.05 log units) above the measured number; measured number inside the range.
By their numbers in this assay, from the lowest: compounds 2 and 3 (each within the scatter of the next); then compound 1.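

In this assay, compound 2 and compound 3 cannot be told apart, with a 1.1-fold higher number from compound 2 to compound 3 (0.06 log units; within the scatter), so methyl in place of hydrogen on this saturated ring carbon leaves the read-out within the scatter. The trifluoromethyl in place of methyl on an aromatic carbon, now isolated, gives a 9.1-fold lower number from compound 1 to compound 3 (0.96 log units; beyond the scatter), so the gap first seen between compound 1 and compound 2 goes with that aromatic group and not with the ring methyl. No available evidence bears on either step. As far as these compounds go, it remains open whether a hydroxyl or a phenyl on this ring carbon would read like methyl, and whether a morpholine could replace the piperidine ring.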